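One five-membered ring swapped for another

This account rests on a few compounds, and the source may have more. Where it says the series, first, only, none or still open, it means among the compounds named here.

In an ADME assay on BJ cells (Homo sapiens) for cytotoxicity, read by MTT assay, with a stated time of 72 h (on this read-out lower numbers stand for higher toxicity in this test and higher numbers for lower toxicity in this test), compound 1 (`OC[C@H]1O[C@@H](n2cc(F)c3c(-c4ccco4)ncnc32)[C@H](O)[C@@H]1O`) gives 310 nM and compound 2 (`OC[C@H]1O[C@@H](n2cc(F)c3c(-c4ccsc4)ncnc32)[C@H](O)[C@@H]1O`) gives 620 nM. These two values lie within the usual scatter of each other, so compound 2 cannot be ranked apart from compound 1.

Compound 3 (`OC[C@H]1O[C@@H](n2cc(F)c3c(-c4ccc[nH]4)ncnc32)[C@H](O)[C@@H]1O`) keeps the shared core but carries 1H-pyrrol-2-yl in place of thiophen-3-yl on an aromatic carbon. Going by the values given here, only one measured step bears on this change, a similar exchange of one five-membered aromatic ring for another, a 2.0-fold higher number from compound 1 to compound 2 (0.30 log units; within the scatter). Among the compounds with values here, no measured compound carries the 1H-pyrrol-2-yl group, so this single step is a weak guide. No step beyond the scatter is expected in this assay, and no firm direction can be given. The estimated value for compound 3 is 500 nM, within an expected range from 150 nM to 1800 nM. This estimate means an expected 1.2-fold lower number from compound 2 to compound 3 (0.09 log units; within the scatter).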

Compound 3, half-maximal cytotoxic concentration: 2990 nM
Compound 3: middle estimate off by 6.0-fold (0.78 log units), on the low side, and the stated range ends below it.
By their numbers in this assay, from the lowest: compounds 1 and 2 (each within the scatter of the next); then compound 3.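

In this assay the swap to 1H-pyrrol-2-yl gives a 4.8-fold higher number from compound 2 to compound 3 (0.68 log units; beyond the scatter) and a 9.6-fold higher number from compound 1 to compound 3 (0.98 log units; beyond the scatter) and so marks compound 3 as the least toxic of the three in this test. Furan-2-yl and thiophen-3-yl could not be told apart, so only now is it clear that exchanging one five-membered aromatic ring for another at this place can move the number beyond the scatter, here with a hydrogen-bond donor entering and a hydrogen-bond acceptor leaving. Nothing available explains this shift.

Whether the hydrogen-bond donor count goes with the higher number cannot be decided from a single compound that carries one. As far as these compounds go, how a six-membered phenyl or pyridine ring, or a simple amine, would read at this place also stays open.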